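Chloro Added to an Amide That Shows Only a Limit

The compounds below may be only part of what the source reports. "The series", "measured", "known", "first", "only" and "open" are said of these compounds alone.

Compound 1 `O=C(Nc1cccc(-n2cc(-c3ccncc3)c(-c3ccc(Cl)c(O)c3)n2)c1)Nc1cccc(C(F)(F)F)c1` gives > 32500 nM in a functional assay on OVCAR-5 cells (Homo sapiens) for inhibition, read by sulforhodamine B assay, with a stated time of 48 h; on this read-out higher numbers stand for weaker inhibition of growth and lower numbers for stronger inhibition of growth.
Compound 2 `COc1cc(-c2nn(-c3cccc(NC(=O)Nc4cc(C(F)(F)F)cc(C(F)(F)F)c4)c3)cc2-c2ccncc2)ccc1Cl` gives 2470 nM in this assay.
Compound 3 `COc1cc(-c2nn(-c3cccc(NC(=O)c4cccc(C(F)(F)F)c4)c3)cc2-c2ccncc2)ccc1Cl` gives > 50000 nM in this assay.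

Of the three measured compounds, only compound 2 returns a number. Compound 3 sits at a limit of the assay, so its true value is not known. Compound 1 likewise sits at a limit of the assay. Within the data shown here, the two limits are given as the limit of > 32500 nM in this assay, at which 1 of the 3 values shown sits, and (the limit of > 50000 nM in this assay, at which 1 of the 3 values shown sits); no step between any two measured compounds is described here, so the account rests on what the values show.

Compound 4 `COc1cc(-c2nn(-c3cccc(NC(=O)c4ccc(Cl)c(C(F)(F)F)c4)c3)cc2-c2ccncc2)ccc1Cl` carries the change (chloro in place of hydrogen on an aromatic carbon). In the words used above, the new group sits ortho to a trifluoromethyl group (4 heavy atoms) and para to a large group. Among the measured compounds shown here, with compound 3 at a limit, no measured step offers guidance, and no shift beyond the usual scatter is expected. Compound 4 is therefore estimated at 45000 nM, with a range of 12000 nM to 100000 nM, a step from compound 3 of an at least 1.1-fold lower number from compound 3 to compound 4 (0.04 log units; that floor lies within the scatter) expected to be small, most likely again reported as a limit.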

Compound 4, concentration for total growth inhibition: > 32500 nM
Compound 4 was reported as a limit (the forecaster's own chance of this, stated with the estimate: 60%); the middle value is on the limit's open side.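

Compound 3 and compound 4 both stand at limits of this assay, and the step between them cannot be read. The compounds shown leave open whether chloro in place of hydrogen on this aromatic carbon shifts inhibition of growth at all.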